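The source may hold more compounds than are shown below. What is called first, only, known or untested is meant among the compounds shown, and "the series" means these compounds.

Measured so far in a functional assay on HCT-116 cells (Homo sapiens) for antiproliferative activity, with a stated time of 48 h (a higher number here means a weaker inhibitor, a lower number a stronger inhibitor), are these two compounds.
- Compound 1 `CCN(CC)c1ccc(-c2cccc(Cl)c2)nn1` gives > 25000 nM (a limit)
- Compound 2 `CCN(CC)c1ccc(-c2cccc(C(F)(F)F)c2)nn1` gives > 25000 nM (a limit)

Compound 2 therefore stands only at a limit of the assay and has no actual number. Compound 3 `FC(F)(F)c1cccc(-c2ccc(N3CCCC3)nn2)c1` differs from it in one group: pyrrolidin-1-yl in place of diethylamino on an aromatic carbon. Among the compounds with values here, the one measured step is a step that the two limits leave unreadable from compound 1 to compound 2 and it changes another place. With the limit of > 25000 nM in this assay, at which 2 of the 2 values shown sit, as the evidence, no size can be carried over, so no change beyond the usual scatter is expected. The estimated step is a step that the limit leaves unreadable from compound 2 to compound 3 and is only tentative. The expected value for compound 3 is 30000 nM in this assay. The estimated range for compound 3 runs from 10000 nM to 80000 nM and another limit is quite possible.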

Compound 3, half-maximal inhibitory concentration: > 25000 nM
Compound 3: a limit, no number; the forecaster's own chance of this, stated with the estimate: 70%; the middle value lies beyond the limit too.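

No step can be read from compound 2 to compound 3, since both stand only at a limit and neither has an actual number: the limit of > 25000 nM in this assay, at which 3 of the 3 values shown sit.

The compounds shown leave open which change on the shared core, if any, would give a real number in this assay.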